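This account rests on a few compounds, and the source may have more. Where it says the series, first, only, none or still open, it means among the compounds named here.

Measured compounds:
compound 1 `Nc1nc(N)c2cc(CSC(=S)N3CCN(c4ccc(F)cc4)CC3)ccc2n1` — 3270 nM
compound 2 `Nc1nc(N)c2cc(CSC(=S)N3CCN(c4ccccc4F)CC3)ccc2n1` — "not determined" (no result reported)

Among the measured compounds shown here, in a functional assay on HCT-116 cells (Homo sapiens) for antiproliferative activity, read by MTT assay, with a stated time of 72 h (on this read-out lower numbers stand for stronger inhibition and higher numbers for weaker inhibition), compound 1 gives 3270 nM, the only number in the set. Compound 2 stands without a result in this assay: it carries no number to compare, so its position relative to compound 1 cannot be stated, and the two are considered only as structures here.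

Compound 3 `Nc1nc(N)c2cc(CSC(=S)N3CCN(c4ccccn4)CC3)ccc2n1` is still to be measured in this assay. The change from compound 2 to compound 3 is pyridin-2-yl in place of 2-fluorophenyl on an amine nitrogen in a ring. For the measured compounds named here, no measured step of this kind exists, so nothing in the data shows which direction the step in this assay would take; without such a step, the working assumption is a change no larger than the usual scatter around the one value available, that of compound 1.

On that basis compound 3 is expected to give about 4000 nM in this assay, within an estimated range of 1000 nM to 16000 nM.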

Compound 3, half-maximal inhibitory concentration: 5960 nM
Compound 3: the middle estimate sits 1.5-fold (0.17 log units) below what was measured, within the range that was stated.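

In this assay, among the compounds shown here, the first readable step at this position is a 1.8-fold higher number from compound 1 to compound 3 (0.26 log units; within the scatter), with pyridin-2-yl replacing 4-fluorophenyl on the amine nitrogen in the ring. Across this single step, a carbon-only aromatic ring with no hydrogen-bond acceptor gives way to a six-membered aromatic ring with one hetero atom and one hydrogen-bond acceptor, and the change stays within the scatter; steps involving compound 2 cannot be read. No measurement on hand offers an explanation for this result.

The compounds shown leave open whether a group of another kind on this nitrogen, such as benzyl, a simple methyl or an acetyl, would give a step beyond the scatter. Also open, on these data alone, is whether pyridin-4-yl or a phenyl ring bearing a carboxylic acid would do so.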